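A few compounds are considered here, and "the series" means these few. Any claim that something is new, unique, unknown or untested is made for them only; others in the source may bear on it.

Working notes on the series, metabolic stability arm.

Three compounds carry numbers in an ADME assay on microsomes from liver (Rattus norvegicus) for metabolic stability; on this read-out lower numbers stand for slow clearance and higher numbers for fast clearance. Compound 1 `CCCC(C#N)(CC)Nc1nc(NC)nc(-n2cncn2)n1` gives 29 mL/min/kg in this assay. Compound 3 `C#CC(CC)(CC)Nc1nc(NC)nc(-n2cncn2)n1` gives 22 mL/min/kg in this assay. Compound 2 `CNc1nc(NC2(C#N)CCCCC2)nc(-n2ccnc2)n1` gives 52 mL/min/kg in this assay, the highest of the three numbers. The gap from compound 2 to compound 1 is within the usual scatter, so the two read as alike. The gap from compound 2 to compound 3 is beyond the scatter, with compound 3 the lower of that pair. For the measured compounds named here, no two measured compounds differ in only one place, so no single structural change has a measured step attached to it.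

Compound 4 `CNc1nc(NC2(C#N)CCCCC2)nc(C2CC2)n1` has not been measured. It differs from compound 2 in one place:

cyclopropyl in place of 1H-imidazol-1-yl on an aromatic carbon

Going by the values given here, nothing in the measured set isolates this change, and no measured pair shows what such a swap on the shared core does to clearance. The step from compound 2 to compound 4 in this assay is therefore expected to be modest and in no firm direction; the working expectation is a 1.2-fold lower number from compound 2 to compound 4 (0.06 log units; within the scatter), treated as no step beyond the scatter. On that basis compound 4 is estimated at 45 mL/min/kg in this assay, with a range from 20 mL/min/kg to 95 mL/min/kg to be revised once the measurement is in hand.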

Compound 4, clearance: 276 mL/min/kg
The estimate for compound 4 lay 6.1-fold (0.79 log units) below the measured number, and the stated range ends below it.
By their numbers in this assay, from the lowest: compounds 3, 1 and 2 (each within the scatter of the next, the first and the last beyond it); then compound 4.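

Cyclopropyl in place of 1H-imidazol-1-yl, on the aromatic carbon between two ring nitrogen atoms, gives a 5.3-fold higher number from compound 2 to compound 4 (0.72 log units; beyond the scatter) in this assay, and this is the only single-place step shown for the series. The position is therefore not a neutral one: with the methylamino group and the rest of compound 2 held fixed, the group on this carbon alone moves clearance well beyond the scatter, towards the fast end of the read-out. Nothing available bears on why this swap produces a step of this size.

Open is whether the higher number follows the departure of 1H-imidazol-1-yl or the arrival of cyclopropyl, as the single swap changes both at once and the compounds shown do not separate the two. Also open, from the compounds shown here alone, is where a methyl group, a methoxy group or an amine such as dimethylamino on this same aromatic carbon would fall relative to compound 2 and compound 4 in this assay, and so whether the number tracks one feature of the group or is particular to cyclopropyl.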